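Heteroaryl swap on the sulfonamide nitrogen of the series

The compounds below may be only part of what the source reports. "The series", "measured", "known", "first", "only" and "open" are said of these compounds alone.

Compound 1 `C=C1CC[C@@H]2[C@](C)(COC(C)=O)[C@H](OC(C)=O)CC[C@@]2(C)[C@H]1CC(Nc1ccc(S(=O)(=O)Nc2ccc(Cl)nn2)cc1)C1=CCOC1=O` gives 4260 nM in a functional assay on A498 cells (Homo sapiens) for inhibition, read by sulforhodamine B assay, with a stated time of 48 h (a lower number here means a stronger inhibitor of growth, a higher number a weaker inhibitor of growth), the lowest number of the three measured. Compound 2 `C=C1CC[C@@H]2[C@](C)(COC(C)=O)[C@H](OC(C)=O)CC[C@@]2(C)[C@H]1CC(Nc1ccc(S(=O)(=O)Nc2cc(C)on2)cc1)C1=CCOC1=O` gives 20300 nM and compound 3 `C=C1CC[C@@H]2[C@](C)(COC(C)=O)[C@H](OC(C)=O)CC[C@@]2(C)[C@H]1CC(Nc1ccc(S(=O)(=O)Nc2ncccn2)cc1)C1=CCOC1=O` gives 24700 nM in this assay. Compound 4 `C=C1CC[C@@H]2[C@](C)(COC(C)=O)[C@H](OC(C)=O)CC[C@@]2(C)[C@H]1CC(Nc1ccc(S(=O)(=O)Nc2nccs2)cc1)C1=CCOC1=O` differs from compound 1 by 1,3-thiazol-2-yl in place of 6-chloropyridazin-3-yl on a sulfonamide nitrogen. Going by the values given here, two measured steps bear on this, both replacing the same 6-chloropyridazin-3-yl group of compound 1: a 4.8-fold higher number from compound 1 to compound 2 (0.68 log units; beyond the scatter) and a 5.8-fold higher number from compound 1 to compound 3 (0.76 log units; beyond the scatter). The 5-methyl-1,2-oxazol-3-yl and pyrimidin-2-yl replacements raised the number by similar amounts, so a step of comparable size towards a higher number is expected in this assay. The expected step is a 3.5-fold higher number from compound 1 to compound 4 (0.55 log units; beyond the scatter). Compound 4 is therefore estimated at 15000 nM, with a range of 5000 nM to 40000 nM.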

Compound 4, concentration for total growth inhibition: 32600 nM
Estimate against measurement, compound 4: 2.2-fold (0.34 log units) below, within the range that was stated.
By their numbers in this assay, from the lowest: compound 1; then compounds 2, 3 and 4 (each within the scatter of the next).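

A third replacement of the 6-chloropyridazin-3-yl group, now 1,3-thiazol-2-yl, again gives a higher number in this assay, with a 7.7-fold higher number from compound 1 to compound 4 (0.88 log units; beyond the scatter). Against the other replacements, it shows a 1.3-fold higher number from compound 3 to compound 4 (0.12 log units; within the scatter) and a 1.6-fold higher number from compound 2 to compound 4 (0.21 log units; within the scatter), so neither ring size nor ring type separates these three, and only compound 1 stands apart. Nothing shown accounts for that gap.

Open, on these data alone, is whether the chlorine or the pyridazine ring carries the lower number of compound 1. A pyridazin-3-yl group without the chlorine, or with methoxy in its place, on the same sulfonamide nitrogen would separate the two.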